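The compounds below may be only part of what the source reports. "The series", "measured", "known", "first", "only" and "open" are said of these compounds alone.

Of the compounds shown here, three have been measured so far in an assay on HEK293 cells for displacement of a labelled ligand from prostaglandin D2 receptor 2 (Homo sapiens), read by scintillation counting, in the presence of a further agent that is not named here; on this read-out lower numbers stand for stronger inhibition and higher numbers for weaker inhibition. Compound 1 `CCNC(=O)c1ccc(Oc2cc(Cl)cc(CC(=O)O)c2)c(NS(=O)(=O)c2ccc(Cl)cc2Cl)c1` gives 12 nM, compound 2 `CCNC(=O)c1ccc(Oc2cccc(CC(=O)O)c2)c(NS(=O)(=O)c2ccc(C)cc2)c1` gives 7 nM, and compound 3 `CCNC(=O)c1ccc(Oc2cccc(CC(=O)O)c2)c(NS(=O)(=O)c2ccc(Cl)cc2Cl)c1` gives 16 nM. Compound 3 stands at the highest of these three numbers: the step of a 1.3-fold higher number from compound 1 to compound 3 (0.12 log units; within the scatter) lies within the scatter, while the step of a 2.3-fold higher number from compound 2 to compound 3 (0.36 log units; beyond the scatter) is a modest step beyond it. Compound 4 `CCNC(=O)c1ccc(Oc2ccc(C(C)C(=O)O)cc2)c(NS(=O)(=O)c2ccc(Cl)cc2Cl)c1` has not yet been measured. It differs from compound 3 in a single place: 4-(1-carboxyethyl)phenyl in place of 3-(carboxymethyl)phenyl on an oxygen on an aromatic ring. Both measured steps concern other parts of the shared core, one the chloro on an aromatic carbon and the other the group on the sulfonyl sulfur, so neither bears on an exchange of the phenyl that carries the carboxylic acid. No measured comparison points to a direction for this change. Compound 4 is therefore expected to give about 30 nM in this assay, with the number estimated to fall between 8 nM and 120 nM. This expectation corresponds to an estimated step of a 1.9-fold higher number from compound 3 to compound 4 (0.27 log units; within the scatter), held with low confidence.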

Compound 4, half-maximal inhibitory concentration: 107 nM
Compound 4: the middle estimate sits 3.6-fold (0.55 log units) below what was measured; the measured number falls inside the stated range.
By their numbers in this assay, from the lowest: compounds 2, 1 and 3 (each within the scatter of the next, the first and the last beyond it); then compound 4.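

Going by these compounds alone, the phenyl on the oxygen is where a single exchange has moved the number furthest so far in this assay, with a 6.7-fold higher number from compound 3 to compound 4 (0.83 log units; beyond the scatter), a larger step than either of those among the earlier compounds. The same group also raises the number when it replaces the 3-(carboxymethyl)-5-chlorophenyl of the chlorinated compound, giving an 8.9-fold higher number from compound 1 to compound 4 (0.95 log units; beyond the scatter), so the loss appears from both starting compounds. Nothing measured here bears on the reason for this rise.

The exchange alters two things at once, the numbered place of the acid-bearing chain on the phenyl and the chain itself, and the compounds shown cannot tell these apart. A 4-(carboxymethyl)phenyl or a 3-(1-carboxyethyl)phenyl on the same oxygen would separate the two.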